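The source may hold more compounds than are shown below. What is called first, only, known or untested is meant among the compounds shown, and "the series" means these compounds.

Compound 1 `Brc1cn2ccnc2c(-c2ccc3ncn(C4CCCCC4)c3c2)n1` — 10.2%
Compound 2 `COc1ccc(-c2cn3ccnc3c(-c3ccc4ncn(C5CCCCC5)c4c3)n2)cc1` — 94.3%
Compound 3 `c1ccc2c(-c3cn4ccnc4c(-c4ccc5ncn(C6CCCCC6)c5c4)n3)cccc2c1` — 2.3%

In a functional assay on SK-MEL-2 cells (Homo sapiens) for inhibition, read by sulforhodamine B assay, with a stated time of 48 h, tested at 10 uM (a lower number here means less inhibition, a higher number more inhibition at the concentration tested (going by the name of the read-out)), compound 2 gives 94.3%, the highest of the three numbers. Compound 1 sits far beneath it, the step being a number 84.1 percentage points higher from compound 1 to compound 2 (beyond the scatter), and compound 3 sits lower still, with a number 92 percentage points lower from compound 2 to compound 3 (beyond the scatter); compound 1 and compound 3 differ from each other only by a number 7.9 percentage points lower from compound 1 to compound 3 (within the scatter).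

Compound 4 `Brc1ccc(-c2cn3ccnc3c(-c3ccc4ncn(C5CCCCC5)c4c3)n2)cc1` has not yet been measured. It comes from compound 2 by bromo in place of methoxy on an aromatic carbon. Among the compounds with values here, no measured step changes this same position, so the bearing steps are indirect: the step from compound 1 to compound 2 shows that putting 4-methoxyphenyl onto the shared core raises inhibition by a large amount, and the step from compound 2 to compound 3 shows that the gain is lost entirely when 4-methoxyphenyl is replaced by naphthalen-1-yl. Compound 4 keeps the phenyl ring that compound 3 lacks, which argues for retained inhibition, but whether the methoxy itself carries the gain cannot be read from these numbers. Compound 4 is therefore expected to land around 60%, between 15% and 95%. The expected step is a number 34.3 percentage points lower from compound 2 to compound 4 (beyond the scatter), a drop that may or may not exceed the scatter.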

Compound 4, a percentage reported as inhibition, at one concentration (the size of the read-out at that concentration, not a potency): 24.1%
Estimate against measurement, compound 4: 35.9 percentage points above; the range from low to high includes it.
By their numbers in this assay, from the lowest: compounds 3 and 1 (each within the scatter of the next); then compound 4; then compound 2.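

In this assay, this position, on an aromatic carbon of a six-membered aromatic ring of carbon only and para to a large group, turns out to be highly sensitive to the group it carries: with bromo in place of methoxy, the result is a number 70.2 percentage points lower from compound 2 to compound 4 (beyond the scatter), so most of the gain seen with 4-methoxyphenyl goes when the methoxy goes. The phenyl ring without methoxy keeps only a small part of that gain, since 4-bromophenyl in place of bromo gives a number 13.9 percentage points higher from compound 1 to compound 4 (beyond the scatter), and 4-bromophenyl in place of naphthalen-1-yl gives a number 21.8 percentage points higher from compound 3 to compound 4 (beyond the scatter), both modest steps beside the large one from methoxy to bromo. Nothing measured here explains why methoxy and bromo differ so sharply at this position.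

As far as these compounds go, whether a hydroxy, an ethoxy or an amine at this same position would hold the inhibition of compound 2 or fall back towards that of compound 4 remains open. Also open is how these single-concentration readings relate to potency, since the compounds shown give no measure of it.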